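Methoxy steps in a short series and an estimate

The source may report more compounds than this note shows. Statements on the series, on what has been measured and on what is new or still open speak of the compounds shown alone.

Compound 1, `Cc1ccc(C(=O)CCc2nnc(-c3ccccc3)o2)cc1`, gives 49.3% in a functional assay on the whole organism (strain Wistar) for inhibition, with Rattus norvegicus as the target, with stated times of 30 min and 3 h, at a dose of 20 mg/kg by the oral route; on this read-out higher numbers stand for more inhibition at the one dose given (going by the name of the read-out) and lower numbers for less inhibition.
Compound 2, `COc1ccc(-c2nnc(CCC(=O)c3ccc(C)cc3)o2)cc1`, gives 89.5% in this assay.
Compound 3, `COc1ccc(-c2nnc(CCC(=O)c3ccc(C)cc3C)o2)cc1`, gives 88.9% in this assay.

The step of a number 40.2 percentage points higher from compound 1 to compound 2 (beyond the scatter) goes with methoxy in place of hydrogen on an aromatic carbon. The step of a number 0.6 percentage points lower from compound 2 to compound 3 (within the scatter) goes with a methyl in place of hydrogen on an aromatic carbon. Compound 3 and compound 1 differ in more than one place, so the difference between their two cores is not broken down here.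

Compound 4, `COc1ccc(-c2nnc(CCC(=O)c3ccc(C)cc3C)o2)cc1OC`, is not yet measured. It differs from compound 3 by methoxy in place of hydrogen on an aromatic carbon. This is the same kind of change as from compound 1 to compound 2, not the same: there the methoxy entered para to a large group, here it enters ortho to a methoxy group and meta to a large group. The step of a number 1.1 percentage points higher from compound 3 to compound 4 (within the scatter) is expected to be small, because compound 3 already gives 88.9% and little room remains upward. Compound 4 is expected to give 90% in this assay, within 72% to 98%.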

Compound 4, a percentage reported as inhibition, in the whole organism at one dose (the size of the read-out at that dose, not a potency): 75.3%
For compound 4 the middle estimate is 14.7 percentage points above the measured one; the range from low to high includes it.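

The same replacement does not carry over as one fixed step between these cores in this assay: the same change on two cores in this assay, a number 40.2 percentage points higher (beyond the scatter) from compound 1 to compound 2 and a number 13.6 percentage points lower (beyond the scatter) from compound 3 to compound 4, 53.8 percentage points apart, beyond the scatter of two such steps. On the core of compound 3 the methoxy, entering ortho to a methoxy group and meta to a large group, goes with a number 13.6 percentage points lower from compound 3 to compound 4 (beyond the scatter), so the earlier gain cannot be assumed for a further methoxy. The two steps differ both in where the methoxy enters and in the core around it, so these compounds do not show which of the two accounts for the gap.

The compounds shown leave open whether a hydroxyl or a chlorine in the same place would go with a similar step. They also leave open how a second methoxy would behave on the core of compound 2, without the added methyl.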